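Taking the ring off the weaker compound

The source may report more compounds than this note shows. Statements on the series, on what has been measured and on what is new or still open speak of the compounds shown alone.

In a functional assay on KARPAS-422 cells (Homo sapiens) for antiproliferative activity, read by resazurin assay, with a stated time of 72 h (a higher number here means a weaker inhibitor, a lower number a stronger inhibitor), compound 1 (`Cc1cc(C)c(CN2CCc3c(Cl)cc([C@H](CO)[C@H]4CCCO4)c(Cl)c3C2=O)c(=O)[nH]1`) gives 63 nM and compound 2 (`Cc1cc(C)c(CN2CCc3c(Cl)cc([C@@H](CO)[C@@H]4CCOC4)c(Cl)c3C2=O)c(=O)[nH]1`) gives 3950 nM. Going by the values given here, compound 2 thus holds the higher, weaker of the only two numbers available. Compound 3 (`Cc1cc(C)c(CN2CCc3c(Cl)cc([C@@H](C)CO)c(Cl)c3C2=O)c(=O)[nH]1`) keeps the shared core but alters the same place on it: a group of 4 heavy atoms (3 carbon, 1 oxygen; no ring) in place of a group of 8 heavy atoms (6 carbon, 2 oxygen; one five-membered non-aromatic ring with 1 hetero atom), on an aromatic carbon. The group carrying the five-membered non-aromatic ring leaves, and a smaller 1-(hydroxymethyl)ethyl group enters on the aromatic carbon.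

Among the compounds with values here, only one measured step bears on this change, and it is large: a 63-fold higher number from compound 1 to compound 2 (1.80 log units; beyond the scatter), well beyond the scatter. That step swaps one ring-bearing group for another of equal size, so it shows that this place matters for these two compounds. It does not show what removing the ring does. The data therefore give only a loose guide, and a moderate move towards a lower number in this assay, smaller than that step, seems the likeliest outcome. The expected change is a 9.9-fold lower number from compound 2 to compound 3 (0.99 log units; beyond the scatter). The estimate for compound 3 is 400 nM, with an expected range from 60 nM to 3000 nM.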

Compound 3, half-maximal inhibitory concentration: 1500 nM
Estimate against measurement, compound 3: 3.8-fold (0.57 log units) below; the measured number falls inside the stated range.
By their numbers in this assay, from the lowest: compound 1; then compound 3; then compound 2.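

Compound 3 shows that the ring itself is not what sets the number, since in this assay cutting the ring-bearing group of compound 2 down to 1-(hydroxymethyl)ethyl gives a 2.6-fold lower number from compound 2 to compound 3 (0.42 log units; beyond the scatter), a modest gain with a smaller group. The same small group measured against the other ring tells the opposite story: methyl in place of oxolan-2-yl gives a 24-fold higher number from compound 1 to compound 3 (1.38 log units; beyond the scatter), a large loss, so the ring of compound 1 goes with a lower number than no ring at all, while the ring of compound 2 goes with a higher one. Compound 3 thus works as a ring-free reference point that the two earlier compounds could not supply on their own, and no measurement shown explains why the two rings fall on opposite sides of it.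

The compounds shown leave open how much of the gap between the two rings comes from the ring itself and how much from the arrangement at the defined stereocentres. They also leave open whether a six-membered oxane ring, an ethyl group or an amine in place of the methyl of compound 3 would sit nearer to compound 1 or to compound 2.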